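The source may report more compounds than this note shows. Statements on the series, on what has been measured and on what is new or still open speak of the compounds shown alone.

In a functional assay on HeLa cells (Homo sapiens) for antiproliferative activity, read by CCK-8 assay, with a stated time of 72 h, tested at 2 uM (on this read-out higher numbers stand for a stronger effect at the one concentration tested and lower numbers for a weaker effect), compound 1 `Nc1ccccc1NC(=O)c1ccc(CSC(=S)N2CCN(c3ccc(Cl)cc3)CC2)cc1` gives 51.2%, the highest of the three numbers; compound 3 `Nc1ccccc1NC(=O)c1ccc(CSC(=S)N2CCCc3ccccc32)cc1` gives 26.1% and compound 2 `CN(C(=S)SCc1ccc(C(=O)Nc2ccccc2N)cc1)c1cccnc1` gives 16%, both lying beyond the scatter below compound 1. Among the measured compounds shown here, the one step measured, a number 10.1 percentage points higher from compound 2 to compound 3 (beyond the scatter), concerns the group on the thiocarbonyl carbon and leaves the halogen untouched. Compound 4 `Nc1ccccc1NC(=O)c1ccc(CSC(=S)N2CCN(c3ccc(F)cc3)CC2)cc1` differs from compound 1 by fluoro in place of chloro on an aromatic carbon. For the measured compounds named here, no measured pair tests this exchange, so the step expected in this assay is small, with no change beyond the scatter and at most a slight fall. The estimate for compound 4 is 45%, between 30% and 60%. The step this expectation implies is a number 6.2 percentage points lower from compound 1 to compound 4 (within the scatter).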

Compound 4, a percentage reported as inhibition, at one concentration (the size of the read-out at that concentration, not a potency): 60.8%
For compound 4 the middle estimate is 15.8 percentage points below the measured one; the whole stated range lies below it.
By their numbers in this assay, from the lowest: compound 2; then compound 3; then compounds 1 and 4 (each within the scatter of the next).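

On the aromatic carbon para to a large group, the exchange of chloro for fluoro gives a number 9.6 percentage points higher from compound 1 to compound 4 (within the scatter) in this assay, so the first test of this change separates the two halogens by no more than the usual scatter. The 4-chlorophenyl and 4-fluorophenyl groups therefore cannot be told apart by this single-concentration read-out. Nothing available explains this result.

Still open, going by these compounds, is whether bromo, methoxy, an amine or plain hydrogen on this carbon would keep the read-out at the same level. Also open, on these data alone, is whether the two halogens would remain inseparable at other concentrations.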